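The source may hold more compounds than are shown below. What is called first, only, known or untested is meant among the compounds shown, and "the series" means these compounds.

Measured so far in a functional assay on MCF7 cells (Homo sapiens), tested at 2.5 uM; on this read-out lower numbers stand for a stronger effect and higher numbers for a weaker effect at the one concentration tested:

Compound 1 `CCOc1cc(/C=C2\SC(=O)NC2=O)ccc1OCC1(C)CCc2c(C)c(OCC=C(C)C)c(C)c(C)c2O1` — compound 1 gives 107%
Compound 2 `C=CCOc1c(C)c(C)c2c(c1C)CCC(C)(COc1ccc(/C=C3\SC(=O)NC3=O)cc1Br)O2` — compound 2 gives 102%
Compound 3 `Cc1c(C)c2c(c(C)c1OCc1ccccc1)CCC(C)(COc1ccc(/C=C3\SC(=O)NC3=O)cc1)O2` — compound 3 gives 85%

Compound 3 stands lowest of the three numbers, and both its distances, to compound 2 as the nearest and to compound 1 as the furthest, lie beyond the usual scatter of this assay. Compound 3 is thus the one with the strongest effect among the measured set, with compound 1 and compound 2 close to no effect at the single concentration.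

Compound 4 `Cc1c(C)c2c(c(C)c1OC/C=C/c1ccccc1)CCC(C)(COc1ccc(/C=C3\SC(=O)NC3=O)cc1)O2` is not yet measured. It differs from compound 3 in one place: 2-phenylethenyl in place of phenyl on a saturated chain carbon bound to an oxygen on an aromatic ring. Among the compounds with values here, no pair of measured compounds shows this change, so there is no measured step to rest on; the only ground is the value of compound 3 itself.

The expectation is a small step, within the scatter, in either direction, written as a number 2 percentage points higher from compound 3 to compound 4 (within the scatter). Compound 4 is estimated at 87%, with a range from 70% to 104%, because compound 3 gives 85% and the change keeps the aromatic ring while adding the double bond outside aromatic rings.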

Compound 4, a percentage reported as activity, at one concentration (the size of the read-out at that concentration, not a potency): 92%
For compound 4 the middle estimate is 5 percentage points below the measured one; the measured number falls inside the stated range.
By their numbers in this assay, from the lowest: compounds 3, 4, 2 and 1 (each within the scatter of the next, the first and the last beyond it).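

In this assay, within the data shown here, 2-phenylethenyl in place of phenyl on a saturated chain carbon bound to an oxygen on an aromatic ring gives a number 7 percentage points higher from compound 3 to compound 4 (within the scatter) and is the first step that can be read at this position. The position therefore takes the added double bond outside aromatic rings, with the aromatic ring kept, without a shift that stands clear of the scatter. Nothing at hand bears on why the read-out holds across this step.

Going by these compounds, both groups in this step carry an aromatic ring, so it remains open whether a saturated 3-phenylpropyl chain would read the same as the 3-phenylprop-2-en-1-yl group. The compounds shown also leave open whether an amine or a carboxylic acid on this chain would move the read-out beyond the scatter.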